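The compounds below may be only part of what the source reports. "The series", "measured", "known", "first", "only" and "open" are said of these compounds alone.

Working notes on the series: in a functional assay on A549 cells (Homo sapiens) for inhibition, read by sulforhodamine B assay, with a stated time of 72 h (on this read-out higher numbers stand for weaker inhibition and lower numbers for stronger inhibition), compound 1 (`Nc1sc(-c2ccc(Cl)cc2)c(-c2ccc(Cl)cc2)c1C(=O)N1CCCCC1=O`) gives 1820 nM, and compound 3 (`CC(C)CNC(=O)c1c(N)sc(-c2ccc(Cl)cc2)c1-c1ccc(Cl)cc1`) gives 21000 nM, the higher of the two numbers and so the weaker inhibition. Compound 2 (`CCN(CC)CCNC(=O)Nc1sc(-c2ccc(Cl)cc2)c(-c2ccc(Cl)cc2)c1C(=O)NC1CC1`) stands in this assay as "not determined" (no result reported), so it adds no number, although it also carries cyclopropyl on an amide-type nitrogen.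

The next comparison is compound 4 (`Nc1sc(-c2ccc(Cl)cc2)c(-c2ccc(Cl)cc2)c1C(=O)NC1CC1`), which has cyclopropyl in place of isobutyl on an amide-type nitrogen.

For the measured compounds named here, only one measured step bears on this, and only indirectly. a 12-fold higher number from compound 1 to compound 3 (1.06 log units; beyond the scatter) is large and beyond the scatter, but it replaces 2-oxopiperidin-1-yl with isobutylamino on a carbonyl carbon. That is a different exchange from isobutylamino to cyclopropylamino, so its size does not carry over. Going by the values given here, no measured pair isolates the present change, which leaves the direction open.

No step beyond the scatter is expected, and the estimated step is a 1.3-fold lower number from compound 3 to compound 4 (0.12 log units; within the scatter). The range is kept wide since it rests on so few numbers. For compound 4 the expected value is 16000 nM, with an estimated range of 5000 nM to 50000 nM.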

Compound 4, half-maximal inhibitory concentration: 1950 nM
Beside the measured number, compound 4's estimate is 8.2-fold (0.91 log units) above it; the measured number lies below the stated range.
By their numbers in this assay, from the lowest: compounds 1 and 4 (each within the scatter of the next); then compound 3.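

Working notes on this position: on the amide-type nitrogen, cyclopropyl in place of isobutyl in this assay gives an 11-fold lower number from compound 3 to compound 4 (1.03 log units; beyond the scatter) as a large step, which is the first measured sign that the group on this nitrogen strongly affects the read-out, even in an exchange as small as isobutyl to cyclopropyl. The change from 2-oxopiperidin-1-yl to cyclopropylamino on the carbonyl carbon gives a 1.1-fold higher number from compound 1 to compound 4 (0.03 log units; within the scatter) and stays within the scatter, so among these three compounds the weak number of compound 3 goes with isobutylamino and not with every amino group at that place. Nothing measured here explains why the exchange of isobutyl for cyclopropyl has so large an effect.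

These compounds do not separate the presence of the three-membered ring from the shortening of the chain, and cyclobutyl or a straight propyl chain on the same nitrogen would bear on that question. On these data alone, how a chain ending in an amine, such as dimethylaminoethyl, or one ending in a carboxylic acid would read at this place also remains open.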